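This account rests on a few compounds, and the source may have more. Where it says the series, first, only, none or still open, it means among the compounds named here.

In an ADME assay on CEM-SS cells (Homo sapiens) for cytotoxicity, read by XTT assay, with a stated time of 6 days (a lower number here means that less compound is tolerated, a higher number that more compound is tolerated), compound 3 (`CCCC(=O)OCSc1ccccc1C(=O)NCC(=O)NC`) gives > 100 uM, and this is a limit of the assay, not a number. Against that, compound 1 (`CCCC(=O)OCSc1ccccc1C(=O)NCCCNC(C)=O`) gives 21.1 uM and compound 2 (`CCCC(=O)OCSc1ccccc1C(=O)NCCCCCCNC(C)=O`) gives 8 uM.

The change to compound 4 (`CCCC(=O)OCSc1ccccc1C(=O)NCC(=O)NCCN(C)C`) is (dimethylamino)methyl in place of hydrogen on a saturated chain carbon bound to an amide-type nitrogen. Cut one bond further out, it reads methylcarbamoyl to (2-(dimethylamino)ethyl)carbamoyl, so the chain on the amide-type nitrogen grows.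

Among the measured compounds shown here, three measured steps bear on this, all made at that same place. The series shows a 2.6-fold lower number from compound 1 to compound 2 (0.42 log units; beyond the scatter), then an at least 4.7-fold higher number from compound 1 to compound 3 (0.67 log units; beyond the scatter), and an at least 12-fold higher number from compound 2 to compound 3 (1.09 log units; beyond the scatter). Across these three compounds the number falls as the chain lengthens, and none of them goes against this. For the measured compounds named here, no measured compound carries the (dimethylamino)methyl group, however, and the two longer chains end in acetamido, so the trend transfers only loosely.

A step of modest size towards a lower number is therefore expected in this assay, closer to the step from compound 1 to compound 2 than to the large one from compound 2 to compound 3. The expected change is an at least 1.6-fold lower number from compound 3 to compound 4 (0.22 log units; that floor lies within the scatter). For compound 4 the estimate is 60 uM, with an expected range of 20 uM to 150 uM. Another limit reading remains a real possibility.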

Compound 4, half-maximal toxic concentration: 76.9 uM
Beside the measured number, compound 4's estimate is 1.3-fold (0.11 log units) below it; low and high end bracket the measured number.
By their numbers in this assay, from the lowest: compound 2; then compound 1; then compound 4. At a limit, above all of these: compound 3.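

In this assay, adding (dimethylamino)methyl on a saturated chain carbon bound to an amide-type nitrogen gives an at least 1.3-fold lower number from compound 3 to compound 4 (0.11 log units; that floor lies within the scatter), so this place accepts the longer (2-(dimethylamino)ethyl)carbamoyl chain with no step shown beyond the scatter. That step can be read only as a floor, because compound 3 stands at a limit of the assay and not at a number: the limit of > 100 uM in this assay, at which 1 of the 4 values shown sits. Compound 4 also stays clear of both chains that end in acetamido, with a 3.6-fold higher number from compound 1 to compound 4 (0.56 log units; beyond the scatter) and a 9.6-fold higher number from compound 2 to compound 4 (0.98 log units; beyond the scatter), so it goes against the earlier fall in the number as the chain lengthens, and chain length alone no longer orders these four compounds.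

Compound 4 differs from the acetamido chains in both the inner carbamoyl and the dimethylamino end, so the compounds shown do not separate what each part contributes to the gap. As far as these compounds go, what a primary amine, a morpholine or a carboxylic acid at the end of the same chain would give in this assay also stays open.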